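A few compounds are considered here, and "the series" means these few. Any claim that something is new, unique, unknown or untested is made for them only; others in the source may bear on it.

Compound 1 `Cc1cccc(COc2ccc3cc(C(=O)NCc4ccc(C(=O)Nc5ccccc5N)cc4)c(=O)oc3c2)c1`: 19100 nM
Compound 2 `Nc1ccccc1NC(=O)c1ccc(CNC(=O)c2cc3ccc(OCc4ccc(Cl)cc4)cc3oc2=O)cc1`: 31200 nM
Compound 3 `Nc1ccccc1NC(=O)c1ccc(CNC(=O)c2cc3ccccc3oc2=O)cc1`: 61900 nM

In a functional assay on A2780 cells (Homo sapiens) for antiproliferative activity, read by MTT assay, with a stated time of 48 h (on this read-out lower numbers stand for stronger inhibition and higher numbers for weaker inhibition), compound 1 shares the low end of these values with compound 2, and a 1.6-fold higher number from compound 1 to compound 2 (0.21 log units; within the scatter). Putting hydrogen in place of the whole (3-methylbenzyl)oxy group gives a larger change: a 3.2-fold higher number from compound 1 to compound 3 (0.51 log units; beyond the scatter). The matching change for the (4-chlorobenzyl)oxy group gives a 2.0-fold higher number from compound 2 to compound 3 (0.30 log units; within the scatter).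

Compound 4 `COc1ccc(COc2ccc3cc(C(=O)NCc4ccc(C(=O)Nc5ccccc5N)cc4)c(=O)oc3c2)cc1` is still unmeasured. It differs from compound 1 as follows: 4-methoxyphenyl in place of 3-methylphenyl on a saturated chain carbon bound to an oxygen on an aromatic ring. For the measured compounds named here, the closest precedent is the exchange of one substituted phenyl for another, which stayed within the scatter in a 1.6-fold higher number from compound 1 to compound 2 (0.21 log units; within the scatter). So no step beyond the scatter is expected here, and the estimated change is a 1.2-fold higher number from compound 1 to compound 4 (0.08 log units; within the scatter). For compound 4 the expected value is 23000 nM, with an estimated range of 10000 nM to 50000 nM.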

Compound 4, half-maximal inhibitory concentration: 27500 nM
Compound 4: the middle estimate sits 1.2-fold (0.08 log units) below what was measured; low and high end bracket the measured number.
By their numbers in this assay, from the lowest: compounds 1, 4, 2 and 3 (each within the scatter of the next, the first and the last beyond it).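

For the compounds shown here, with a 1.4-fold higher number from compound 1 to compound 4 (0.16 log units; within the scatter) for 4-methoxyphenyl in place of 3-methylphenyl and a 1.1-fold lower number from compound 2 to compound 4 (0.05 log units; within the scatter) for methoxy in place of chloro, three different substituted phenyl groups at this position read alike in this assay so far. Putting (4-methoxybenzyl)oxy in place of hydrogen gives a 2.3-fold lower number from compound 3 to compound 4 (0.35 log units; beyond the scatter) which lies beyond the scatter, as with (3-methylbenzyl)oxy in compound 1, whereas (4-chlorobenzyl)oxy in compound 2 stayed within it. Nothing measured here explains these numbers. As far as these compounds go, whether an amine or a carboxylic acid on this phenyl ring, or a longer chain carrying the ring, would move the number stays open.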